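Swapping the Benzyl Halogen in a Triazole-Linked Series

The source may report more compounds than this note shows. Statements on the series, on what has been measured and on what is new or still open speak of the compounds shown alone.

Compound 1 `Cc1ccc(/C=C2\CN(Cc3cn(Cc4ccc(F)cc4)nn3)C/C(=C\c3ccc(C)cc3)C2=O)cc1`: 49700 nM
Compound 2 `Cc1ccc(/C=C2\CN(C(=S)SCc3cn(Cc4ccc(F)cc4)nn3)C/C(=C\c3ccc(C)cc3)C2=O)cc1`: 38800 nM
Compound 3 `Cc1ccc(/C=C2\CN(C(=S)SCc3cn(Cc4cccc(Cl)c4)nn3)C/C(=C\c3ccc(C)cc3)C2=O)cc1`: > 80000 nM, a limit of the assay rather than a number

In a functional assay on DU-145 cells (Homo sapiens) for cytotoxicity, read by MTT assay, with a stated time of 24 h (a lower number here means a stronger inhibitor, a higher number a weaker inhibitor), compound 1 gives 49700 nM, and compound 2 gives 38800 nM; these two values sit within the usual scatter of each other. How the cores of compound 1 and compound 2 differ is not broken down here. For compound 3 the assay returns only a limit, > 80000 nM. The change 3-chlorophenyl in place of 4-fluorophenyl on a saturated chain carbon bound to an aromatic nitrogen brought an at least 2.0-fold higher number from compound 2 to compound 3 (0.31 log units; beyond the scatter), consistent with the limit of > 80000 nM in this assay, at which 1 of the 3 values shown sits.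

Compound 4 `Cc1ccc(/C=C2\CN(Cc3cn(Cc4cccc(Cl)c4)nn3)C/C(=C\c3ccc(C)cc3)C2=O)cc1` carries the same change on compound 1: 3-chlorophenyl in place of 4-fluorophenyl on a saturated chain carbon bound to an aromatic nitrogen. The step is expected to be a 2.0-fold higher number from compound 1 to compound 4 (0.30 log units; within the scatter), resting on an at least 2.0-fold higher number from compound 2 to compound 3 (0.31 log units; beyond the scatter). Compound 4 is therefore estimated at 100000 nM, likely between 50000 nM and 200000 nM, with a real chance that this assay again reports only a limit.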

Compound 4, half-maximal inhibitory concentration: 33100 nM
The estimate for compound 4 lay 3.0-fold (0.48 log units) above the measured number; measured number outside the range, below it.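

In this assay, the swap of 4-fluorobenzyl to 3-chlorobenzyl on the core of compound 1 gives a 1.5-fold lower number from compound 1 to compound 4 (0.18 log units; within the scatter), a step too small to tell from repeat-measurement noise. The change therefore did not carry over unchanged from the core of compound 2, and the two outcomes differ by more than noise: the same change on two cores in this assay, an at least 2.0-fold higher number (0.31 log units; beyond the scatter) from compound 2 to compound 3 and a 1.5-fold lower number (0.18 log units; within the scatter) from compound 1 to compound 4, at least 3.0-fold (0.49 log units) apart, beyond the scatter of two such steps This shows that the step cannot be assumed to transfer between these two cores, but not how it behaves on any other core, and the value for compound 3 is a limit rather than a number: the limit of > 80000 nM in this assay, at which 1 of the 4 values shown sits.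

Halogen and ring position change together in this swap, so their separate contributions stay open. As far as these compounds go, how a benzyl group carrying a methoxy group or a nitrile would behave on either core also stays open.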